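A Smaller Cap: Phenyl Gives Way to Isopropyl

The compounds below may be only part of what the source reports. "The series", "measured", "known", "first", "only" and "open" are said of these compounds alone.

Three measured compounds share one core and differ only in the group attached to a carbonyl carbon. Compound 1 `O=C(/C=C/c1ccccc1)N[C@@H](CCCCCC(=O)NO)C(=O)Nc1cccc2cccnc12` gives 1240 nM in a functional assay on NFF cells (Homo sapiens) for antiproliferative activity; on this read-out higher numbers stand for weaker inhibition and lower numbers for stronger inhibition. Compound 2 `O=C(CCCCC[C@H](NC(=O)c1ccc(C(F)(F)F)cc1)C(=O)Nc1cccc2cccnc12)NO` gives 696 nM in this assay, and compound 3 `O=C(CCCCC[C@H](NC(=O)OCc1ccccc1)C(=O)Nc1cccc2cccnc12)NO` gives 452 nM, the lowest of the three numbers, though its gap to compound 2 is within the scatter. The steps of a 1.8-fold lower number from compound 1 to compound 2 (0.25 log units; within the scatter), a 2.7-fold lower number from compound 1 to compound 3 (0.44 log units; beyond the scatter) and a 1.5-fold lower number from compound 2 to compound 3 (0.19 log units; within the scatter) show that exchanging this group moves the number only modestly. Compound 4 `CC(C)COC(=O)N[C@@H](CCCCCC(=O)NO)C(=O)Nc1cccc2cccnc12` differs from compound 3 by isopropyl in place of phenyl on a saturated chain carbon bound to an oxygen next to a carbonyl group. Within the data shown here, no measured step removes a ring at this position, so there is no direct guide; the modest steps seen so far suggest a small move at most. Compound 4 is expected to give 750 nM, within a range from 300 nM to 1800 nM. The step of a 1.7-fold higher number from compound 3 to compound 4 (0.22 log units; within the scatter) is therefore expected to stay within the scatter.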

Compound 4, half-maximal inhibitory concentration: 81 nM
The estimate for compound 4 lay 9.3-fold (0.97 log units) above the measured number, and the stated range ends above it.
By their numbers in this assay, from the lowest: compound 4; then compounds 3, 2 and 1 (each within the scatter of the next, the first and the last beyond it).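

Isopropyl in place of phenyl at this place brings a 5.6-fold lower number from compound 3 to compound 4 (0.75 log units; beyond the scatter), so in this assay this group need not end in a ring, and the gap exceeds any seen among the earlier compounds. Isobutoxy also stands well apart from the other two groups, with an 8.6-fold lower number from compound 2 to compound 4 (0.93 log units; beyond the scatter) and a 15-fold lower number from compound 1 to compound 4 (1.18 log units; beyond the scatter). No evidence is available to explain this gain. Still open, on these data alone, is whether losing the aromatic ring or having fewer carbons matters more: a cyclohexyl group, which keeps a ring without aromaticity, or a longer chain such as n-hexyl could separate the two.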